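The source may report more compounds than this note shows. Statements on the series, on what has been measured and on what is new or still open speak of the compounds shown alone.

Measured so far in a functional assay on MDA-MB-231 cells (Homo sapiens) for antiproliferative activity, read by MTT assay; a higher number here means a weaker inhibitor, a lower number a stronger inhibitor: compound 1 `CNC(=O)c1ccc(Oc2cccc(NC(=S)Nc3ccc(F)cc3)c2)nc1` gives 21700 nM; compound 2 `CNC(=O)c1ccc(Oc2cccc(NC(=S)Nc3ccc(F)c(Cl)c3)c2)nc1` gives 28600 nM; compound 3 `CNC(=O)c1ccc(Oc2cccc(NC(=S)Nc3ccc(OC)cc3)c2)nc1` gives 31500 nM.

Compound 1 holds the lowest of the three numbers, yet a 1.3-fold higher number from compound 1 to compound 2 (0.12 log units; within the scatter) and a 1.5-fold higher number from compound 1 to compound 3 (0.16 log units; within the scatter) both sit within the scatter, so the three compounds stand together rather than apart.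

Compound 4 `CNC(=O)c1ccc(Oc2cccc(NC(=S)Nc3cccc(C(F)(F)F)c3)c2)nc1` is not yet measured. Its change from compound 1: 3-(trifluoromethyl)phenyl in place of 4-fluorophenyl on an amide-type nitrogen. Within the data shown here, the steps that bear on it are those that also alter the ring on the thiourea nitrogen, a 1.3-fold higher number from compound 1 to compound 2 (0.12 log units; within the scatter) and a 1.5-fold higher number from compound 1 to compound 3 (0.16 log units; within the scatter), neither of which left the scatter. On that basis no step beyond the scatter is expected in this assay for compound 4, in either direction; the expected step is a 1.2-fold higher number from compound 1 to compound 4 (0.06 log units; within the scatter). Compound 4 is therefore estimated at 25000 nM, within 11000 nM to 60000 nM.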

Compound 4, half-maximal inhibitory concentration: 38100 nM
Estimate against measurement, compound 4: 1.5-fold (0.18 log units) below; the range from low to high includes it.
By their numbers in this assay, from the lowest: compounds 1, 2, 3 and 4 (each within the scatter of the next).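

In this assay, 3-(trifluoromethyl)phenyl on the amide-type nitrogen leaves every comparison within the scatter: (a 1.8-fold higher number from compound 1 to compound 4 (0.24 log units; within the scatter)), (a 1.3-fold higher number from compound 2 to compound 4 (0.12 log units; within the scatter)) and (a 1.2-fold higher number from compound 3 to compound 4 (0.08 log units; within the scatter)). Trifluoromethyl thus joins fluoro, chloro and methoxy as a ring substituent at this position, and none of the four compounds separates from the others. No measurement available here bears on the reason for this flat result.

As far as these compounds go, whether an amine or a carboxylic acid on this ring would give a step beyond the scatter stays open. So does the effect of replacing the ring with a longer alkyl chain.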